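Swapping an Ester Side Chain for an Amine

The compounds below may be only part of what the source reports. "The series", "measured", "known", "first", "only" and "open" are said of these compounds alone.

Compound 1 `CC(=O)OCc1ccc2oc(=O)c(C(=O)Oc3cccc(Cl)c3)cc2c1` gives 95.2% in a functional assay on HT-1080 cells (Homo sapiens), read by transwell migration, with a stated time of 24 h, tested at 0.1 uM; a lower number here means a stronger effect, a higher number a weaker effect of the compound at the concentration tested.
Compound 2 `CCC(=O)OCc1ccc2oc(=O)c(C(=O)Oc3cccc(Br)c3)cc2c1` gives 84.4% in this assay.
Compound 3 `O=C(Oc1cccc(Cl)c1)c1cc2cc(CCl)ccc2oc1=O` gives 98.4% in this assay.

Compound 2 has the lowest of the three numbers, so it shows the strongest effect; compound 1 is nearest to it and compound 3 furthest, both beyond the usual scatter. Compound 4 `NCc1ccc2oc(=O)c(C(=O)Oc3cccc(Br)c3)cc2c1` differs from compound 2 by amino in place of propanoyloxy on a saturated chain carbon bound to an aromatic carbon. Among the compounds with values here, the only measured step at that same place is a number 3.2 percentage points higher from compound 1 to compound 3 (within the scatter), which stayed within the scatter. On that evidence little change is expected in this assay, at most a small rise. Compound 4 is therefore estimated at 89%, with a range from 77% to 100%. That estimate means an expected step of a number 4.6 percentage points higher from compound 2 to compound 4 (within the scatter).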

Compound 4, a percentage reported as activity, at one concentration (the size of the read-out at that concentration, not a potency): 88.3%
The estimate for compound 4 lay 0.7 percentage points above the measured number; low and high end bracket the measured number.
By their numbers in this assay, from the lowest: compounds 2, 4, 1 and 3 (each within the scatter of the next, the first and the last beyond it).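

In this assay, amino in place of propanoyloxy gives a number 3.9 percentage points higher from compound 2 to compound 4 (within the scatter) and so shows that even a single nitrogen with a hydrogen-bond donor, replacing a whole ester of five heavy atoms, leaves the read-out within the scatter. Until now, this saturated chain carbon had only shown that result for chloro in place of acetoxy. No measurement here gives a reason for this result. Going by these compounds, whether a carboxylic acid or a longer chain ending in an amine would read the same at this place remains open.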